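The source may hold more compounds than are shown below. What is called first, only, known or untested is meant among the compounds shown, and "the series" means these compounds.

Measured compounds:
compound 1 `CC(C)OC(=O)N1CCC2(CC1)CC(CCCOc1ccc(S(C)(=O)=O)c(F)c1)C2` — < 0.16 ug/mL in a physicochemical assay for solubility, read by HPLC, in phosphate buffer, with a stated time of 24 h, at pH 6.8 (on this read-out lower numbers stand for lower solubility and higher numbers for higher solubility), a limit of the assay
compound 2 `CC1(OC(=O)N2CCC3(CC2)CC(CCCOc2ccc(S(C)(=O)=O)c(F)c2)C3)CC1` — < 0.15 ug/mL, a limit of the assay
compound 3 `CS(=O)(=O)c1ccc(OCCCC2CC3(CCN(C(=O)OC4CCCC4)CC3)C2)cc1F` — < 0.14 ug/mL, a limit of the assay

All three values in this assay are limits, so compound 1 stands at a limit, (the limit of < 0.16 ug/mL in this assay, at which 1 of the 3 values shown sits), and the two further values are limits as well, the limit of < 0.14 ug/mL in this assay, at which 1 of the 3 values shown sits, and (the limit of < 0.15 ug/mL in this assay, at which 1 of the 3 values shown sits). The three measured steps are a step that the two limits leave unreadable from compound 1 to compound 2, a step that the two limits leave unreadable from compound 1 to compound 3 and a step that the two limits leave unreadable from compound 2 to compound 3; each of them changes the group on the oxygen of the carbamate, and none of them can be read in size.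

Compound 4 `CC(C)OC(=O)N1CCC2(CC1)CC(CCCOc1ccc(C(=O)N3CCCC3)c(F)c1)C2` differs from compound 1 by (pyrrolidin-1-yl)carbonyl in place of methylsulfonyl on an aromatic carbon. Within the data shown here, this change is on the aromatic ring and not on the carbamate, so none of the measured steps bears on it, and the measured steps would give no readable size even if they did. The expectation for compound 4 therefore rests only on the limit at which compound 1 sits, and the step of an at least 1.8-fold higher number from compound 1 to compound 4 (0.27 log units; that floor lies within the scatter) is estimated with wide uncertainty. In this assay compound 4 is expected to give about 0.3 ug/mL, with a range from 0.05 ug/mL to 2 ug/mL.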

Compound 4, solubility: 3.85 ug/mL
Beside the measured number, compound 4's estimate is 13-fold (1.11 log units) below it; measured number above the stated range.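

In this assay, among these compounds, (pyrrolidin-1-yl)carbonyl in place of methylsulfonyl on the aromatic carbon ortho to a fluoro group gives an at least 24-fold higher number from compound 1 to compound 4 (1.38 log units; beyond the scatter), the only step that can be read in size. Among the compounds shown here, the steps among compound 1, compound 2 and compound 3, all at the carbamate oxygen, cannot be read, so this aromatic position is the first place where a single change gives a measured number. The step is a floor and not a full size, as the value of compound 1 is a limit of the assay: the limit of < 0.16 ug/mL in this assay, at which 1 of the 4 values shown sits.

The compounds shown leave open whether the carbonyl or the pyrrolidine ring carries the step, a question on which (morpholin-4-yl)carbonyl or a carboxylic acid in the same place would bear. They also leave open whether the carbamate groups of compound 2 and compound 3 would read apart when paired with (pyrrolidin-1-yl)carbonyl.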